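This account rests on a few compounds, and the source may have more. Where it says the series, first, only, none or still open, it means among the compounds named here.

Compound 1 `COc1ccc(-c2cc(-c3ccccc3)no2)c(OCCCN2CCCCC2)c1` gives 20.8% in a functional assay on the whole organism (blood, strain Charles Foster/Wistar albino) with Rattus norvegicus as the target, with a stated time of 30 min, at a dose of 100 mg/kg by the oral route; on this read-out lower numbers stand for less inhibition and higher numbers for more inhibition at the one dose given (going by the name of the read-out). Compound 2 `COc1ccc(-c2cc(-c3ccccc3)no2)c(OCC(=O)O)c1` gives 11.7% in this assay. Compound 3 `CCOC(=O)CCCOc1cc(OC)ccc1-c1cc(-c2ccccc2)no1` gives 4.6% in this assay.

Compound 3 has the lowest of the three numbers, though its gap to compound 2 lies within the scatter and only its gap to compound 1 lies beyond it. Compound 4 `COc1ccc(-c2cc(-c3ccccc3)no2)c(O)c1` differs from compound 3 in one place: hydrogen in place of 3-(ethoxycarbonyl)propyl on an oxygen on an aromatic ring. Among the compounds with values here, none of the measured steps removes the whole chain, but all three alter the end of the chain on that oxygen: a number 16.2 percentage points lower from compound 1 to compound 3 (beyond the scatter), a number 7.1 percentage points lower from compound 2 to compound 3 (within the scatter) and a number 9.1 percentage points lower from compound 1 to compound 2 (within the scatter). Every variant at this position gives a low number, so only a small step is expected, a number 5.4 percentage points higher from compound 3 to compound 4 (within the scatter), with no clear direction. Compound 4 is therefore expected to give 10%, most likely between 0% and 25%.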

Compound 4, a percentage reported as inhibition, in the whole organism at one dose (the size of the read-out at that dose, not a potency): 9.8%
Beside the measured number, compound 4's estimate is 0.2 percentage points above it; low and high end bracket the measured number.
By their numbers in this assay, from the lowest: compounds 3, 4, 2 and 1 (each within the scatter of the next, the first and the last beyond it).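

With the whole chain gone, the hydroxy compound cannot be told apart from the two variants carrying an ester or an acid on that oxygen in this assay: there is a number 5.2 percentage points higher from compound 3 to compound 4 (within the scatter) and a number 1.9 percentage points lower from compound 2 to compound 4 (within the scatter). Only 3-(piperidin-1-yl)propyl stands apart, with a number 11 percentage points lower from compound 1 to compound 4 (beyond the scatter), so among these four compounds this is the one chain that separates from plain hydrogen on this oxygen. Nothing measured here explains that gap. As far as these compounds go, whether a shorter or longer chain ending in piperidin-1-yl, or the same chain ending in dimethylamino or morpholin-4-yl, would give a similar number remains open.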